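Swapping a fluorophenyl for a pyridyl on a fused-ring scaffold

This account rests on a few compounds, and the source may have more. Where it says the series, first, only, none or still open, it means among the compounds named here.

Compound 1 `CC(C)(C)c1ccc(NC(=S)N/N=C2\C(=O)Nc3ccccc32)cc1`: 6800 nM
Compound 2 `CCOC(=O)CC1C(C(=O)OCC)=C(N)Oc2ccc(-c3ccccc3F)cc21`: 73000 nM

Of the compounds shown here, two have been measured in a functional assay on HL-60 cells (Homo sapiens) for cytotoxicity, read by CellTiter-Blue, with a stated time of 48 h; a lower number here means a stronger inhibitor, a higher number a weaker inhibitor. Compound 1 gives 6800 nM and compound 2 gives 73000 nM. Of these two numbers, compound 2 has the higher one, and its gap to compound 1 lies beyond the usual scatter of the assay. The two compounds share no common core, so the gap between them cannot be traced to any single structural change.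

Going by the values given here, compound 3 `CCOC(=O)CC1C(C(=O)OCC)=C(N)Oc2ccc(-c3ccncc3)cc21` keeps the whole core of compound 2 and changes only one group: pyridin-4-yl in place of 2-fluorophenyl on an aromatic carbon. Among the compounds with values here, no measured pair in this set isolates such a swap, so there is no step on which to base the size or direction of the change. In the absence of any such anchor, the step from compound 2 to compound 3 in this assay is expected to stay within the scatter, with no clear direction. The estimated step is no change at the digits printed from compound 2 to compound 3 (within the scatter). Compound 3 is therefore estimated at 73000 nM, within a range from 25000 nM to 200000 nM.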

Compound 3, half-maximal inhibitory concentration: 10200 nM
For compound 3 the middle estimate is 7.2-fold (0.85 log units) above the measured one; measured number outside the range, below it.
By their numbers in this assay, from the lowest: compounds 1 and 3 (each within the scatter of the next); then compound 2.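

In this assay, going by these compounds alone, pyridin-4-yl in place of 2-fluorophenyl on an aromatic carbon gives a 7.2-fold lower number from compound 2 to compound 3 (0.85 log units; beyond the scatter), the first step in this set that isolates a single change. It shows that the group at this position of the shared core can move the number, and that here the ring with one nitrogen and one hydrogen-bond acceptor goes with the lower number than the fluorinated all-carbon ring. No measurement bears on why the number moves with this change.

The swap removes the fluorine and brings in the ring nitrogen in one step, so the compounds shown cannot say which of the two accounts for the difference, and plain phenyl or pyridin-3-yl at the same carbon would be needed to pull them apart. They also leave open whether this position accepts groups of another kind, such as an amine or a carboxylic acid, and whether the step from the 2-fluorophenyl to the pyridin-4-yl would hold on a core with other ester groups.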